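Chloro to methoxy on the aryl ring of compound 3

A few compounds are considered here, and "the series" means these few. Any claim that something is new, unique, unknown or untested is made for them only; others in the source may bear on it.

Measured compounds:
compound 1, `Cc1nnc(SCC(=O)N/N=c2/scc(-c3ccccc3)n2-c2ccccc2)s1`, 72.4% in a functional assay on C6 cells (Rattus norvegicus) for cytotoxicity, read by MTT assay, with a stated time of 24 h, tested at 6 ug/mL; a lower number here means a stronger effect, a higher number a weaker effect of the compound at the concentration tested
compound 2, `Cc1nnc(SCC(=O)N/N=c2/scc(-c3ccc(F)cc3)n2-c2ccccc2)s1`, 74.3%
compound 3, `Cc1nnc(SCC(=O)N/N=c2/scc(-c3ccc(Cl)cc3)n2-c2ccccc2)s1`, 82.8%

Compound 3 has the highest of the three numbers; its gap to compound 1 is beyond the scatter a number 10.4 percentage points higher from compound 1 to compound 3 (beyond the scatter), while its gap to compound 2 is within it a number 8.5 percentage points higher from compound 2 to compound 3 (within the scatter). Compound 4, `COc1ccc(-c2cs/c(=N/NC(=O)CSc3nnc(C)s3)n2-c2ccccc2)cc1`, differs from compound 3 as follows: methoxy in place of chloro on an aromatic carbon. Going by the values given here, no measured step involves a methoxy group, so only the steps at this carbon bear on it: a number 1.9 percentage points higher from compound 1 to compound 2 (within the scatter) and a number 10.4 percentage points higher from compound 1 to compound 3 (beyond the scatter). Among the compounds with values here, both substituents nudged the number upward in this assay, but the methoxy group has no precedent here, so no step beyond the scatter is expected from compound 3 to compound 4. Compound 4 is thus estimated at 78%, within 66% to 90%, an expected step of a number 4.8 percentage points lower from compound 3 to compound 4 (within the scatter).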

Compound 4, a percentage reported as activity, at one concentration (the size of the read-out at that concentration, not a potency): 57.9%
For compound 4 the middle estimate is 20.1 percentage points above the measured one, outside the stated range (below it).
By their numbers in this assay, from the lowest: compound 4; then compounds 1, 2 and 3 (each within the scatter of the next, the first and the last beyond it).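

At this position, para to a large group, the earlier changes had only raised the number in this assay or left it within the scatter, whereas the methoxy group lowers it, giving a number 14.5 percentage points lower from compound 1 to compound 4 (beyond the scatter), a number 16.4 percentage points lower from compound 2 to compound 4 (beyond the scatter) and a number 24.9 percentage points lower from compound 3 to compound 4 (beyond the scatter). The position therefore responds in both directions, and the outcome depends on the group placed there. No evidence is available to explain this reversal. As far as these compounds go, it remains open whether an ethoxy group, a hydroxyl group or an amine at this carbon would also lower the number. From the compounds shown here alone, whether a methoxy group would do so elsewhere on that ring also remains open.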